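Swapping the aryl amine on a urea

This account rests on a few compounds, and the source may have more. Where it says the series, first, only, none or still open, it means among the compounds named here.

Compound 1, `COc1cc(NC(=O)Nc2cc(Nc3ccc(C(C)(C)C)cc3)ncn2)cc(OC)c1`, is one of three ureas measured in a functional assay on NCI-H520 cells (Homo sapiens) for inhibition, read by MTT assay, with a stated time of 48 h, tested at 10 uM; on this read-out higher numbers stand for more inhibition at the one concentration tested (going by the name of the read-out) and lower numbers for less inhibition. In this assay compound 1 gives 17.5%, the lowest of the three numbers. Compound 2, `Cc1ccc(Nc2cc(NC(=O)Nc3c(Cl)cccc3Cl)ncn2)cc1C`, gives 47.5% in this assay, and compound 3, `COc1cc(Nc2cc(NC(=O)Nc3c(Cl)cccc3Cl)ncn2)cc(OC)c1`, gives 55.5%; both of these lie beyond the scatter above compound 1, but each differs from compound 1 in more than one place, so their gaps cannot be tied to a single change. Compound 4, `COc1cc(NC(=O)Nc2cc(Nc3cc(I)ccc3OC)ncn2)cc(OC)c1`, keeps the core and the urea of compound 1 and differs only in the aryl group on the amine: 5-iodo-2-methoxyphenyl in place of 4-(tert-butyl)phenyl on a nitrogen on an aromatic ring. Among the compounds with values here, no measured pair shows this change by itself, so its effect has to be guessed. Compound 4 is expected to sit a little higher than compound 1, with the step from a number 12.5 percentage points higher from compound 1 to compound 4 (beyond the scatter) probably modest and possibly still within the scatter. The estimate for compound 4 in this assay is 30%, expected to fall between 10% and 55%.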

Compound 4, a percentage reported as inhibition, at one concentration (the size of the read-out at that concentration, not a potency): 55%
Estimate against measurement, compound 4: 25 percentage points below, within the range that was stated.
By their numbers in this assay, from the lowest: compound 1; then compounds 2, 4 and 3 (each within the scatter of the next).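

In this assay, putting 5-iodo-2-methoxyphenyl in place of 4-(tert-butyl)phenyl on a nitrogen on an aromatic ring gives a number 37.5 percentage points higher from compound 1 to compound 4 (beyond the scatter) and is the only single-place change shown. With the core and the urea held the same, the aryl group on this amine nitrogen can by itself move the read-out by a large step, beyond the scatter. No evidence at hand accounts for the size of this step.

Since the whole aryl group changes at once, the compounds shown leave open whether the iodine, the methoxy group or the loss of the tert-butyl group carries the step. They also leave open how the read-out would respond at this position to an aryl group bearing a smaller halogen such as fluorine, or a carboxylic acid.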